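A few compounds are considered here, and "the series" means these few. Any claim that something is new, unique, unknown or untested is made for them only; others in the source may bear on it.

Working notes on the series. Compound 1 `O=C(CO[N+](=O)[O-])NNC(=O)c1ccc(-n2[nH]c(=O)cc2-c2ccccc2O)cc1` gives 19.3% in a functional assay on the whole organism (strain Wistar) for inhibition, with Rattus norvegicus as the target, read by paw edema, with stated times of 2 h and 1 h, at a dose of 6 mg/kg by the oral route; a higher number here means more inhibition at the dose given (going by the name of the read-out), a lower number less inhibition. Compound 2 `CCOC(=O)c1c(-c2ccc([N+](=O)[O-])cc2)n(-c2ccc(C(=O)NNC(=O)CO[N+](=O)[O-])cc2)[nH]c1=O` gives 28.1%. Compound 3 `CCOC(=O)c1c(-c2ccccc2OC)n(-c2ccc(C(=O)NNC(=O)CO[N+](=O)[O-])cc2)[nH]c1=O` gives 30.7%, the largest of the three numbers; the gap to compound 2 lies within the scatter, so those two cannot be ordered, and only compound 1 stands apart beyond the scatter. Going by the values given here, the single one-place step measured so far, a number 2.6 percentage points higher from compound 2 to compound 3 (within the scatter), is itself within the scatter.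

Compound 4 `CCOC(=O)c1c(-c2ccccc2O)n(-c2ccc(C(=O)NNC(=O)CO[N+](=O)[O-])cc2)[nH]c1=O` is the next member, differing from compound 3 by hydrogen in place of methyl on an oxygen on an aromatic ring, that is methoxy to hydroxy on the aryl group carried by the shared core. Among the compounds with values here, no measured step changes this oxygen's substituent with the rest of the molecule held fixed, so nothing bears directly on it. Compound 1, which carries the 2-hydroxyphenyl, gives 19.3%, and compound 3, with the 2-methoxyphenyl, gives 30.7%, but the two also differ in the ester on the core and in the lactam, so the comparison is loose. The expected step, a number 4.7 percentage points lower from compound 3 to compound 4 (within the scatter), is small and of uncertain direction. Compound 4 is therefore estimated at 26%, with a range from 16% to 36%.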

Compound 4, a percentage reported as inhibition, in the whole organism at one dose (the size of the read-out at that dose, not a potency): 26.6%
Compound 4: the middle estimate sits 0.6 percentage points below what was measured, within the range that was stated.
By their numbers in this assay, from the lowest: compounds 1, 4, 2 and 3 (each within the scatter of the next, the first and the last beyond it).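

In this assay, the oxygen on the aromatic ring now has a direct reading with the rest of the molecule held fixed: hydrogen in place of methyl gives a number 4.1 percentage points lower from compound 3 to compound 4 (within the scatter), so methoxy and hydroxy cannot be told apart at this dose. The aryl group also has a second reading, with 2-hydroxyphenyl in place of 4-nitrophenyl giving a number 1.5 percentage points lower from compound 2 to compound 4 (within the scatter), and taken with a number 2.6 percentage points higher from compound 2 to compound 3 (within the scatter), this leaves the three aryl groups carried alongside the ethoxycarbonyl unordered. Going by these compounds alone, the first reading on the ester, ethoxycarbonyl in place of hydrogen on an aromatic carbon, gives a number 7.3 percentage points higher from compound 1 to compound 4 (within the scatter), so every one-place step still lies within the scatter, even though this one is the largest of them.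

No measurement at hand offers an explanation for the size of any of these steps. Still open, on these data alone, are a carboxylic acid or a primary amide in place of the ethoxycarbonyl, and an ethyl or longer chain in place of the methyl on the oxygen, either of which might give a step that stands clear of the scatter.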